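The source may report more compounds than this note shows. Statements on the series, on what has been measured and on what is new or still open speak of the compounds shown alone.

Three compounds that share one core were examined in an ADME assay on Vero cells (Chlorocebus sabaeus) for cytotoxicity, read by sulforhodamine B assay, with a stated time of 72 h; on this read-out higher numbers stand for weaker inhibition and lower numbers for stronger inhibition. Compound 1, with the structure `CN1Cc2ccc(OCc3ccccc3)cc2[C@@H](O)C1`, gives a result that is only a limit of the assay, namely > 100000 nM. Compound 2, with the structure `CN1Cc2ccc(OCCC3CCCCC3)cc2[C@@H](O)C1`, likewise gives only a limit, namely > 50000 nM. The structural difference between the two is cyclohexylmethyl in place of phenyl on a saturated chain carbon bound to an oxygen on an aromatic ring, and the step it makes in this assay is a step that the two limits leave unreadable from compound 1 to compound 2. Compound 3, with the structure `CN1Cc2ccc(O)cc2[C@@H](OCc2ccccc2)C1`, is built from the same atoms as compound 1 joined differently, and the difference between the two cores is not broken down here. In this assay compound 3 also stops at a limit, namely > 50000 nM. The unmeasured compound 4, with the structure `CN1Cc2ccc(O)cc2[C@@H](OCCC2CCCCC2)C1`, differs from compound 3 by cyclohexylmethyl in place of phenyl on a saturated chain carbon bound to an oxygen on a saturated carbon. This is the same kind of change as that between compound 1 and compound 2, but not the same one: there the place is on a saturated chain carbon bound to an oxygen on an aromatic ring, here it is on a saturated chain carbon bound to an oxygen on a saturated carbon. All that is known so far comes from limits, as the limit of > 100000 nM in this assay, at which 1 of the 3 values shown sits, and the limit of > 50000 nM in this assay, at which 2 of the 3 values shown sit, show. Beside the earlier step, the step expected in this assay is a number no higher from compound 3 to compound 4 (the limit leaves the size open) because of the limit of > 50000 nM in this assay, at which 2 of the 3 values shown sit. Compound 4 is therefore estimated to give 50000 nM, most likely once more as a limit rather than a number.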

Compound 4, half-maximal inhibitory concentration: > 50000 nM
Compound 4 gave a limit, no number; the forecaster's own chance of this, stated with the estimate: 85%; the middle value lies on the limit itself.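

In this assay compound 4 gives > 50000 nM, which is a limit of the assay and not a number. For the compounds shown here, compound 3 also gives only a limit there, and no step from compound 3 to compound 4 can be read. The compounds shown leave open at what concentration, if any, each would inhibit the cells, and whether cyclohexylmethyl in place of phenyl changes that concentration.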